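Aryl swap at the fused core: compound 4 expected

The source may report more compounds than this note shows. Statements on the series, on what has been measured and on what is new or still open speak of the compounds shown alone.

Compound 3 `CCCS(=O)(=O)Nc1ccc(F)c(C(=O)c2n[nH]c3ncc(-c4ccc(Cl)cc4Cl)cc23)c1F` stands second highest of the three measured numbers in an assay for binding affinity to dual specificity mitogen-activated protein kinase kinase 4 (Homo sapiens), read by KINOMEscan, tested at 100 nM (on this read-out higher numbers stand for a weaker effect at the one concentration tested and lower numbers for a stronger effect), with compound 3 giving 22%; compound 1 `CCCS(=O)(=O)Nc1ccc(F)c(C(=O)c2n[nH]c3ncc(-c4ccccc4N)cc23)c1F` gives 23%, and a number 1 percentage points lower from compound 1 to compound 3 (within the scatter), so the two cannot be ordered. Compound 2 `CCCS(=O)(=O)Nc1ccc(F)c(C(=O)c2n[nH]c3ncc(-c4ccc(N(C)C)cc4)cc23)c1F` gives 2.5%, and a number 19.5 percentage points higher from compound 2 to compound 3 (beyond the scatter), while a number 20.5 percentage points lower from compound 1 to compound 2 (beyond the scatter).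

Compound 4 `CCCS(=O)(=O)Nc1ccc(F)c(C(=O)c2n[nH]c3ncc(-c4ccc(S(N)(=O)=O)cc4C)cc23)c1F` differs from compound 3 only at the same aromatic carbon: 2-methyl-4-sulfamoylphenyl in place of 2,4-dichlorophenyl on an aromatic carbon. All three measured steps change the aryl group at this position, and they span from no change to a modest step in this assay. The 2-methyl-4-sulfamoylphenyl group of compound 4 has no measured neighbour, so the direction of any step is open; a modest step in either direction is possible and none beyond the scatter is also plausible.

Compound 4 is therefore estimated at 15% in this assay, within 3% to 45%, which means an expected step of a number 7 percentage points lower from compound 3 to compound 4 (within the scatter).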

Compound 4, a percentage reported as activity, at one concentration (the size of the read-out at that concentration, not a potency): 3.1%
Compound 4: the middle estimate sits 11.9 percentage points above what was measured; measured number inside the range.
By their numbers in this assay, from the lowest: compounds 2 and 4 (each within the scatter of the next); then compounds 3 and 1 (each within the scatter of the next).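

In this assay, the aryl position on the shared core now has a second group at the low end, with a number 18.9 percentage points lower from compound 3 to compound 4 (beyond the scatter) and a number 19.9 percentage points lower from compound 1 to compound 4 (beyond the scatter) while a number 0.6 percentage points higher from compound 2 to compound 4 (within the scatter) shows no separation from the 4-(dimethylamino)phenyl compound. Among the earlier compounds, the 2-aminophenyl and 2,4-dichlorophenyl groups both gave the higher numbers, but the 2-methyl-4-sulfamoylphenyl group shows that a substituent numbered 2 on the phenyl does not by itself go with them. A group numbered 4 is not enough either, as the 2,4-dichlorophenyl of compound 3 goes against that reading.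

The compounds shown do not separate the share of the methyl from that of the sulfamoyl, which a plain 4-sulfamoylphenyl or 2-methylphenyl group would address. Nothing available explains why the number falls with this change.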